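Aryl group swaps and cell toxicity in one amine series

This account rests on a few compounds, and the source may have more. Where it says the series, first, only, none or still open, it means among the compounds named here.

Measured in an ADME assay on Huh-7 cells (Homo sapiens) for cytotoxicity; on this read-out higher numbers stand for lower toxicity in this test and lower numbers for higher toxicity in this test:
compound 1 `Cc1ccccc1-c1nn(-c2ccc(Br)cc2)cc1CNCCN1CCN(C)CC1` gives 9600 nM
compound 2 `Cc1ccccc1-c1nn(-c2ccc(OC(F)(F)F)cc2)cc1CNCCN1CCN(C)CC1` gives 17000 nM
compound 3 `CSc1ccc(-n2cc(CNCCN3CCN(C)CC3)c(-c3ccccc3C)n2)cc1` gives 17000 nM

Compound 3 stands level with compound 2 at the digits printed, the two together the highest of the three numbers in this assay; compound 1 is the furthest from it, and that gap is within the scatter. The three measured steps all lie within the scatter: a 1.8-fold higher number from compound 1 to compound 2 (0.25 log units; within the scatter), a 1.8-fold higher number from compound 1 to compound 3 (0.25 log units; within the scatter) and no change at the digits printed from compound 2 to compound 3 (within the scatter). Swapping the group on this aryl ring has so far moved nothing that can be told from repeat measurement.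

Compound 4 `Cc1ccccc1-c1nn(-c2ccc(F)c(F)c2)cc1CNCCN1CCN(C)CC1` is not yet measured. It differs from compound 3 by 3,4-difluorophenyl in place of 4-(methylsulfanyl)phenyl on an aromatic nitrogen. The change again touches only the aryl group on the ring nitrogen, the same place varied in all three measured steps, which each stayed within the scatter. For the measured compounds named here, no step bearing on this position has yet moved the number beyond the scatter, so the expectation for compound 4 is a step of a 1.2-fold lower number from compound 3 to compound 4 (0.08 log units; within the scatter), that is, none beyond the scatter, in this assay.

Compound 4 is therefore estimated at 14000 nM in this assay, with a range of 6000 nM to 32000 nM.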

Compound 4, half-maximal cytotoxic concentration: > 20000 nM
Compound 4: no number, only a limit; the forecaster's own chance of this, stated with the estimate: 10%; middle value at least 1.4-fold (0.15 log units) from the limit.
By their numbers in this assay, from the lowest: compounds 1, 2 and 3 (each within the scatter of the next). At a limit, above all of these: compound 4.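

The reading for compound 4 in this assay is a limit of the assay and not a number: the limit of > 20000 nM in this assay, at which 1 of the 4 values shown sits. Even so, 3,4-difluorophenyl in place of 4-bromophenyl on the aromatic nitrogen gives the only step at this position that clears the scatter, an at least 2.0-fold higher number from compound 1 to compound 4 (0.31 log units; beyond the scatter), so this aryl group is no longer shown to be without effect on the read-out. Against the other two aryl groups the floors stay within the scatter, an at least 1.1-fold higher number from compound 3 to compound 4 (0.07 log units; that floor lies within the scatter) and an at least 1.1-fold higher number from compound 2 to compound 4 (0.07 log units; that floor lies within the scatter), so compound 4 is not separated from 4-(methylsulfanyl)phenyl or 4-(trifluoromethoxy)phenyl, and the gain over 4-bromophenyl remains a floor of unknown full size.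

How far compound 4 lies past its limit cannot be read from these compounds, and neither can whether one fluorine would behave as the two do, as a 4-fluorophenyl group would show. Also open, from the compounds shown here alone, is how an amine or a carboxylic acid on this aryl ring would read, since all four compounds carry only neutral groups there and share the 2-methylphenyl group and the amine side chain.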